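Sulfonamide aryl swap in a melanoma cytotoxicity series

The source may hold more compounds than are shown below. What is called first, only, known or untested is meant among the compounds shown, and "the series" means these compounds.

Measured compounds:
compound 1, `COc1cc(-c2nc(-c3ccccc3)[nH]c2-c2ccnc(NCCCNS(=O)(=O)c3ccc(Cl)cc3)n2)ccc1F`, 83100 nM
compound 2, `COc1cc(-c2nc(-c3ccccc3)[nH]c2-c2ccnc(NCCCNS(=O)(=O)c3ccc(Br)cc3)n2)ccc1F`, 33900 nM

Two compounds share a core and differ only in the aryl group on the sulfonyl sulfur. In a functional assay on LOX IMVI cells (Homo sapiens) for cytotoxicity, read by MTT assay, with a stated time of 24 h (on this read-out lower numbers stand for stronger inhibition and higher numbers for weaker inhibition), compound 1 gives 83100 nM, the highest of the two numbers; its nearest neighbour is compound 2, which gives 33900 nM in this assay. Among the measured compounds shown here, the single step between them, a 2.5-fold lower number from compound 1 to compound 2 (0.39 log units; beyond the scatter), is modest but lies beyond the scatter.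

Compound 3, `COc1cc(-c2nc(-c3ccccc3)[nH]c2-c2ccnc(NCCCNS(=O)(=O)c3cccc(F)c3)n2)ccc1F`, has not yet been measured in this assay. It differs from compound 1 as follows: 3-fluorophenyl in place of 4-chlorophenyl on a sulfonyl sulfur. For the measured compounds named here, no measured step covers this exact exchange; the only step known here replaces one aryl group on the same sulfonyl sulfur by another and moved the number by a 2.5-fold lower number from compound 1 to compound 2 (0.39 log units; beyond the scatter). That step gives a sense of scale but does not fix a direction for compound 3, so no change beyond the scatter is firmly expected, with a slight lean toward a weaker read-out. Compound 3 is therefore estimated at 100000 nM in this assay, with a range from 30000 nM to 300000 nM, which corresponds to an expected step of a 1.2-fold higher number from compound 1 to compound 3 (0.08 log units; within the scatter).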

Compound 3, half-maximal inhibitory concentration: 900 nM
Compound 3: middle estimate off by 110-fold (2.05 log units), on the high side; measured number outside the range, below it.
By their numbers in this assay, from the lowest: compound 3; then compound 2; then compound 1.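

Moving to 3-fluorophenyl on the sulfonyl sulfur gives a 92-fold lower number from compound 1 to compound 3 (1.97 log units; beyond the scatter) and a 38-fold lower number from compound 2 to compound 3 (1.58 log units; beyond the scatter) in this assay and so shows that this position can move the read-out far more than the modest 2.5-fold lower number from compound 1 to compound 2 (0.39 log units; beyond the scatter) between the two 4-halophenyl compounds had suggested. Compound 3, at 900 nM in this series, has the lowest number of the three, and its steps to both other compounds are printed as beyond the scatter, even though the group that leaves and the group that enters match in heavy atoms, hydrogen-bond donors, hydrogen-bond acceptors and net charge. Nothing available bears on why this exchange has so large an effect.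

The exchange changes both the halogen and its place on the ring, and the compounds shown cannot say which of the two accounts for the step. They also leave open what an unsubstituted phenyl, or a phenyl carrying a methoxy group or an amine, would give on the same sulfonyl sulfur.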